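The source may hold more compounds than are shown below. What is called first, only, known or untested is meant among the compounds shown, and "the series" means these compounds.

Compound 2 `CSc1ccc(F)cc1NCC1=NCCN1` stands lowest of the two numbers measured in an assay for binding affinity to Alpha-1D adrenergic receptor (Homo sapiens), read by radioligand binding (a higher number here means a weaker inhibitor, a lower number a stronger inhibitor), where compound 2 gives 6.17 nM. Compound 1 `CSc1ccc(C)cc1NCC1=NCCN1` gives 17.4 nM in this assay, and the measured step from it was a 2.8-fold lower number from compound 1 to compound 2 (0.45 log units; beyond the scatter). Compound 3 `CSc1ccc(Cl)cc1NCC1=NCCN1` differs from compound 2 by chloro in place of fluoro on an aromatic carbon. Among the compounds with values here, the only measured step bears on this change indirectly: it replaced methyl with fluoro, and no step compares chloro with fluoro. Compound 3 is therefore expected to show no step beyond the scatter, a 1.0-fold lower number from compound 2 to compound 3 (0.01 log units; within the scatter). Compound 3 is estimated at 6 nM, within a range from 2.5 nM to 15 nM.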

Compound 3, inhibition constant: 4.68 nM
For compound 3 the middle estimate is 1.3-fold (0.11 log units) above the measured one, and the stated range covers the measured number.
By their numbers in this assay, from the lowest: compounds 3 and 2 (each within the scatter of the next); then compound 1.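

In this assay, chloro and fluoro on this aromatic carbon are not separated, with a 1.3-fold lower number from compound 2 to compound 3 (0.12 log units; within the scatter). Chloro in place of methyl gives a 3.7-fold lower number from compound 1 to compound 3 (0.57 log units; beyond the scatter), so the lower number seen with fluoro is shared by a second halogen at this position. No measurement at hand accounts for these steps. The compounds shown leave open whether bromo, methoxy or an amine at this position would fall with the two halogens or with methyl. They also leave open whether these steps hold once the methylsulfanyl group is replaced.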